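The compounds below may be only part of what the source reports. "The series", "measured", "known", "first", "only" and "open" are said of these compounds alone.

Compound 1 `CC1=C(C(=O)Nc2ccc(Cl)c(Cl)c2)C(c2cccc(Oc3ccccc3)c2)NC(=S)N1` gives 6170 nM in a functional assay on SF-268 cells (Homo sapiens) for cytotoxicity, read by sulforhodamine B assay, with a stated time of 48 h; a higher number here means a weaker inhibitor of growth, a lower number a stronger inhibitor of growth.
Compound 2 `CC1=C(C(=O)Nc2ccc(F)c(Cl)c2)C(c2cccc(Cl)c2)NC(=S)N1` gives 10000 nM in this assay.

Both compounds share one core and differ in the groups hung on it. In this assay compound 1 sits close to compound 2, and the gap between them is within the scatter, so the two cannot be told apart on these numbers. Compound 3 `COc1cccc(C2NC(=S)NC(C)=C2C(=O)Nc2ccc(Cl)c(Cl)c2)c1` has not yet been measured in this assay. It differs from compound 1 in one place: methyl in place of phenyl on an oxygen on an aromatic ring. Among the compounds with values here, no pair of measured compounds shows what this change does here, so the step can only be expected. A modest shift toward a higher number is expected, meaning a weaker inhibitor of growth, but one that may not rise beyond the scatter, so the step of a 1.6-fold higher number from compound 1 to compound 3 (0.21 log units; within the scatter) is estimated small. For compound 3 the estimate in this assay is 10000 nM, with a range from 4000 nM to 30000 nM.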

Compound 3, concentration for 50% growth inhibition: 12600 nM
Beside the measured number, compound 3's estimate is 1.3-fold (0.10 log units) below it; the range from low to high includes it.
By their numbers in this assay, from the lowest: compounds 1, 2 and 3 (each within the scatter of the next, the first and the last beyond it).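

Compound 1 and compound 3 differ only in the group on an oxygen on an aromatic ring, so this pair isolates one change: phenoxy to methoxy gives, in this assay, a 2.0-fold higher number from compound 1 to compound 3 (0.31 log units; beyond the scatter). This means that the group at this position can affect growth inhibition, with phenyl on the oxygen giving the stronger inhibitor of this pair, although the shift is modest and only just clears the usual scatter. The data shown give no measurement that explains the shift.

This conclusion rests on a single pair, so it is not yet a trend across the series. From the compounds shown here alone, it remains open whether a longer chain such as ethyl, a benzyl group or a free hydroxyl on the same ring would behave more like compound 1 or compound 3.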